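The compounds below may be only part of what the source reports. "The series", "measured", "known", "first", "only" and "open" are said of these compounds alone.

Three compounds share one core and differ only in the group carried on an amide-type nitrogen. Compound 1 `COc1cccc(NC(=O)COc2ccc3cc(/C=C4/SC(=O)NC4=O)ccc3c2)c1` carries a 3-methoxyphenyl group there, and in an assay on isolated protein for inhibition of histone deacetylase 8 (Homo sapiens), with a stated time of 1 h (on this read-out lower numbers stand for stronger inhibition and higher numbers for weaker inhibition), compound 1 gives 7600 nM. Compound 2 `O=C(COc1ccc2cc(/C=C3/SC(=O)NC3=O)ccc2c1)Nc1ccccn1` carries a pyridin-2-yl group instead. In this assay compound 2 gives > 50000 nM, which is a limit of the measurement rather than a number. Compound 3 `COc1ccc(NC(=O)COc2ccc3cc(/C=C4/SC(=O)NC4=O)ccc3c2)cc1` carries a 4-methoxyphenyl group. In this assay compound 3 gives > 50000 nM, again a limit. Compound 2 therefore stands at the weak end of what has been measured, sharing the limit of > 50000 nM in this assay, at which 2 of the 3 values shown sit, with compound 3. The move to it was an at least 6.5-fold higher number from compound 1 to compound 2 (0.81 log units; beyond the scatter), the parallel move was an at least 6.5-fold higher number from compound 1 to compound 3 (0.81 log units; beyond the scatter), and a step that the two limits leave unreadable from compound 2 to compound 3 cannot be sized.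

Compound 4 `O=C(COc1ccc2cc(/C=C3/SC(=O)NC3=O)ccc2c1)Nc1cc(Cl)cc(C(F)(F)F)c1` is not yet measured. Its difference from compound 2 is this: 3-chloro-5-(trifluoromethyl)phenyl in place of pyridin-2-yl on an amide-type nitrogen. Among the compounds with values here, the step that bears on this is the one between compound 1 and compound 2, because an at least 6.5-fold higher number from compound 1 to compound 2 (0.81 log units; beyond the scatter) shows a substituted phenyl giving a lower number than pyridin-2-yl; compound 3, however, shows that a substituted phenyl can also sit at the limit. The step expected from this is an at least 5.0-fold lower number from compound 2 to compound 4 (0.69 log units; beyond the scatter). Compound 4 is estimated at 10000 nM, with a range from 2500 nM to 50000 nM.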

Compound 4, half-maximal inhibitory concentration: > 50000 nM
Compound 4: only a limit was reported (the forecaster's own chance of this, stated with the estimate: 35%); middle value at least 5.0-fold (0.69 log units) away from the limit.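

Compound 4 gives only a limit of the measurement in this assay, as compound 2 and compound 3 do: the limit of > 50000 nM in this assay, at which 3 of the 4 values shown sit. Replacing the 3-methoxyphenyl group of compound 1 with the larger 3-chloro-5-(trifluoromethyl)phenyl group gives an at least 6.5-fold higher number from compound 1 to compound 4 (0.81 log units; beyond the scatter), so a second substituted phenyl group on this amide-type nitrogen, after the 4-methoxyphenyl group of compound 3, fails to reach a readable value. Among the four compounds, compound 1 alone gives a number, 7600 nM, which suggests that a phenyl ring here is not enough and that its particular substituents matter. The steps among compound 2, compound 3 and compound 4 cannot be read, as each joins two limits.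

On these data alone, how much weaker compound 2, compound 3 and compound 4 are than the limit, and whether they differ from one another, stays unknown. Also open, as far as these compounds go, is which feature of compound 1 gives it a readable value, a question that an unsubstituted phenyl ring, or a phenyl ring carrying an amine or a carboxylic acid, on the same nitrogen could help to answer.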